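The source may hold more compounds than are shown below. What is called first, only, known or untested is meant among the compounds shown, and "the series" means these compounds.

Two compounds share a core in which a carbon doubly bonded to nitrogen carries two amide-type nitrogens, each bearing a furan-derived acyl group. Compound 1 `C[Se]/C(=N\C(=O)c1ccco1)NC(=O)c1ccco1` carries a methylselanyl group on that carbon, and compound 2 `CS/C(=N\C(=O)c1ccco1)NC(=O)c1ccco1` carries a methylsulfanyl group there. In a functional assay on MCF7 cells (Homo sapiens) for cytotoxicity, read by MTT assay, with a stated time of 72 h (a higher number here means a weaker inhibitor of growth, a lower number a stronger inhibitor of growth), compound 1 gives 30 nM, while compound 2 gives 56100 nM, the higher of the two numbers seen. Among the compounds with values here, the single step measured, a 1900-fold higher number from compound 1 to compound 2 (3.27 log units; beyond the scatter), shows how much the swap of selenium for sulfur changed the result.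

Compound 3 `O=C(/N=C(/NC(=O)c1ccco1)[Se]Cc1ccccc1)c1ccco1` is the next compound to be measured. It differs from compound 2 in one place: a group of 8 heavy atoms (7 carbon, 1 selenium; one six-membered aromatic ring of carbon only) in place of a group of 2 heavy atoms (1 carbon, 1 sulfur; no ring), on a carbon with a double bond to nitrogen. Within the data shown here, this change brings selenium back, so the one measured step bears on it and points toward a large fall in the number. What the benzyl group adds beyond that is not known from these data. Compound 3 is therefore expected to show a 940-fold lower number from compound 2 to compound 3 (2.97 log units; beyond the scatter), giving an estimate of 60 nM with a range from 10 nM to 400 nM.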

Compound 3, concentration for 50% growth inhibition: 8800 nM
The estimate for compound 3 lay 150-fold (2.17 log units) below the measured number; the measured number lies above the stated range.
By their numbers in this assay, from the lowest: compound 1; then compound 3; then compound 2.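

In this assay, selenium on this carbon does not by itself ensure a low number: phenyl in place of hydrogen on the saturated chain carbon bound to selenium gives a 290-fold higher number from compound 1 to compound 3 (2.47 log units; beyond the scatter). Replacing methylsulfanyl with the larger selenium group gives only a 6.4-fold lower number from compound 2 to compound 3 (0.80 log units; beyond the scatter), so the large gain seen with the methyl group on selenium does not carry over in full, and what is attached to selenium matters as well as the selenium itself. Nothing measured here accounts for these differences.

A benzyl group on sulfur at the same carbon would show how much selenium matters when the phenyl ring is present. On these data alone, it also remains open whether an ethyl group on selenium would give a number closer to that of compound 1 or to that of compound 3.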